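The compounds below may be only part of what the source reports. "The series", "measured", "known", "first", "only" and "open" are said of these compounds alone.

Compound 1 `NC(=O)c1cnc(N2CCN(S(=O)(=O)c3ccccc3C(F)(F)F)CC2)s1`: in an assay on microsomes from liver (strain Wistar) for inhibition of acyl-CoA desaturase 1 (Rattus norvegicus), read by HPLC, with stated times of 1 h and 60 min (on this read-out lower numbers stand for stronger inhibition and higher numbers for weaker inhibition), compound 1 gives > 3000 nM, which is a limit of the assay and not a number.
Compound 2 `NC(=O)c1cnc(N2CCC(Oc3ccccc3C(F)(F)F)CC2)s1`: compound 2 gives 3 nM.

Compound 2 holds the only number shown; the other entry is a limit (the limit of > 3000 nM in this assay, at which 1 of the 2 values shown sits). Compound 3 `NC(=O)c1nc(N2CCC(Oc3ccccc3C(F)(F)F)CC2)no1` differs from compound 2 by 5-carbamoyl-1,2,4-oxadiazol-3-yl in place of 5-carbamoyl-1,3-thiazol-2-yl on an amine nitrogen in a ring, with the oxadiazole carrying the carbamoyl as before. Going by the values given here, no measured step covers such a ring swap. The expectation for compound 3 is a modest loss, a 3.3-fold higher number from compound 2 to compound 3 (0.52 log units; beyond the scatter), a step not far beyond the usual scatter. Compound 3 is estimated at 10 nM, within 2 nM to 60 nM.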

Compound 3, half-maximal inhibitory concentration: 1630 nM
Beside the measured number, compound 3's estimate is 160-fold (2.21 log units) below it, and the stated range ends below it.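

The exchange of 5-carbamoyl-1,3-thiazol-2-yl for 5-carbamoyl-1,2,4-oxadiazol-3-yl in this assay gives a 540-fold higher number from compound 2 to compound 3 (2.74 log units; beyond the scatter), so this place on the amine nitrogen in a ring is sensitive to the identity of the five-membered aromatic ring, even with the carbamoyl kept. The rest of the molecule is unchanged, so the whole step belongs to this one exchange. Nothing shown gives a cause for the step.

A single exchange cannot separate the loss of the ring sulfur from the gain of a ring nitrogen. Going by these compounds, a 1,3-oxazole carrying the same carbamoyl, or a nitrile in place of the carbamoyl on the thiazole, remains open.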